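Head-group exchange on the saturated chain

A few compounds are considered here, and "the series" means these few. Any claim that something is new, unique, unknown or untested is made for them only; others in the source may bear on it.

Among the measured compounds shown here, compound 2 `CCCCCCCCCCCCCCCCCC1OCC(COCCCCCC[n+]2cscc2C)O1` gives 3.1 mg/kg in a functional assay on artery with platelet-activating factor receptor (Rattus norvegicus) as the target (on this read-out higher numbers stand for an effect only at larger amounts of compound and lower numbers for an effect already at smaller amounts), the only plain number in the set. Compound 1 `CCCCCCCCCCCCCCCCCC1OCC(COCCCCCC[n+]2ccccc2)O1` reaches only a limit of this assay, > 5 mg/kg. For the measured compounds named here, the single measured step, an at least 1.6-fold lower number from compound 1 to compound 2 (0.20 log units; that floor lies within the scatter), rests on that limit of > 5 mg/kg in this assay, at which 1 of the 2 values shown sits, and so fixes neither size nor direction firmly. Compound 3 `CCCCCCCCCCCCCCCCCC1OCC(COCCCCCC[n+]2cccc3ccccc32)O1` carries a group of 10 heavy atoms (9 carbon, 1 nitrogen; one six-membered aromatic ring of carbon only, one six-membered aromatic ring with 1 hetero atom) in place of a group of 6 heavy atoms (4 carbon, 1 nitrogen, 1 sulfur; one five-membered aromatic ring with 2 hetero atoms), on a saturated chain carbon, six bonds along the chain from an oxygen on a saturated carbon. Going by the values given here, no measured step touches the group that enters here, so the change is untested. For compound 3 a step of a 1.3-fold higher number from compound 2 to compound 3 (0.11 log units; within the scatter) is expected, not beyond the scatter. Compound 3 is estimated at 4 mg/kg, between 1.5 mg/kg and 12 mg/kg.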

Compound 3, dose for 50% inhibition: 3.8 mg/kg
Compound 3: middle estimate off by 1.1-fold (0.02 log units), on the high side; the measured number falls inside the stated range.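

Among the compounds shown here, the exchange at this saturated chain carbon, six bonds along the chain from an oxygen on a saturated carbon, gives the first step between two plain numbers: a 1.2-fold higher number from compound 2 to compound 3 (0.09 log units; within the scatter). The group of 10 heavy atoms and the group of 6 heavy atoms with sulfur are therefore not told apart in this assay. The value of compound 1 is a limit. Resting on it stands an at least 1.3-fold lower number from compound 1 to compound 3 (0.11 log units; that floor lies within the scatter) and this step cannot be read as a firm size or direction: the limit of > 5 mg/kg in this assay, at which 1 of the 3 values shown sits.

The compounds shown leave open whether a trimethylammonium head group, or a longer chain before the ring, would move the number beyond the scatter.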